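Removing the benzoyl from compound 2: what to expect

This account rests on a few compounds, and the source may have more. Where it says the series, first, only, none or still open, it means among the compounds named here.

Among the compounds with values here, compound 2 `Nc1ncccc1-c1nc2cccnc2n1-c1ccc(NC(=O)c2ccccc2)cc1` holds the lowest of the two numbers measured in an in vitro assay on Sf9 cells for inhibition of RAC-alpha serine/threonine-protein kinase (Homo sapiens), read by AlphaScreen, with a stated time of 20 min (a lower number here means a stronger inhibitor, a higher number a weaker inhibitor), where compound 2 gives 14 nM; the only other measured compound, compound 1 `Nc1ncccc1-c1nc2cc(C3CCCC3)cnc2n1-c1ccc(CNC(=O)c2ccccc2)cc1`, gives 110 nM in this assay, a difference beyond the scatter. Compound 3 `Nc1ccc(-n2c(-c3cccnc3N)nc3cccnc32)cc1` differs from compound 2 by hydrogen in place of benzoyl on a nitrogen on an aromatic ring, so the benzamido becomes an amino group. Within the data shown here, no measured pair shows this change, so the step is a guess; a loss of potency beyond the scatter in this assay is expected, the step from compound 2 to compound 3 being estimated as an 11-fold higher number from compound 2 to compound 3 (1.03 log units; beyond the scatter). Compound 3 is therefore expected to give about 150 nM in this assay, within 40 nM to 600 nM.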

Compound 3, half-maximal inhibitory concentration: 740 nM
Beside the measured number, compound 3's estimate is 4.9-fold (0.69 log units) below it; the measured number lies above the stated range.
By their numbers in this assay, from the lowest: compound 2; then compound 1; then compound 3.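

Cutting the benzamido back to an amino group gives a 53-fold higher number from compound 2 to compound 3 (1.72 log units; beyond the scatter) in this assay, the first direct reading at this position. It shows that, on this core, the benzoyl on the nitrogen cannot be removed without a large loss of potency. Nothing available explains the size of this loss. The compounds shown leave open which part of the benzoyl matters, the carbonyl or the six-membered aromatic ring. An acetyl or a benzyl on the same nitrogen would separate the two.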